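The source may hold more compounds than are shown below. What is called first, only, known or untested is meant among the compounds shown, and "the series" means these compounds.

Compound 3 `COc1ccc(C[C@H]2COC(=O)[C@@H]2Cc2ccc(OCc3cn(Cc4ccccc4)nn3)c(OC)c2)cc1OC` carries a benzyl group on the triazole nitrogen, and compound 4 `COc1ccc(C[C@H]2COC(=O)[C@@H]2Cc2ccc(OCc3cn(-c4ccc(C)cc4)nn3)c(OC)c2)cc1OC` is its untested neighbour. In an ADME assay on HeLa cells (Homo sapiens) for cytotoxicity, read by MTT assay (a lower number here means a stronger inhibitor, a higher number a weaker inhibitor), compound 3 gives 346000 nM, the lowest of the two numbers shown. Compound 2 `COc1ccc(C[C@H]2COC(=O)[C@@H]2Cc2ccc(OCc3cn(-c4cccc(Cl)c4)nn3)c(OC)c2)cc1OC` gives 493000 nM in this assay. Compound 1 `COc1ccc(C[C@H]2COC(=O)[C@@H]2Cc2ccc(OCc3cn(Cc4ccccc4F)nn3)c(OC)c2)cc1OC` gives only a limit in this assay, >= 600000 nM, described by the limit of >= 600000 nM in this assay, at which 1 of the 3 values shown sits. The shift a 1.4-fold lower number from compound 2 to compound 3 (0.15 log units; within the scatter) swaps 3-chlorophenyl for benzyl on that nitrogen, and an at least 1.2-fold lower number from compound 1 to compound 2 (0.08 log units; that floor lies within the scatter) and an at least 1.7-fold lower number from compound 1 to compound 3 (0.23 log units; that floor lies within the scatter) rest on a limit. The change to compound 4 is 4-methylphenyl in place of benzyl on an aromatic nitrogen. Putting an aryl group back on that nitrogen echoes the step between compound 2 and compound 3, so a shift a 1.2-fold higher number from compound 3 to compound 4 (0.08 log units; within the scatter) is expected, nothing beyond the scatter. Compound 4 is therefore expected near 420000 nM, between 220000 nM and 800000 nM.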

Compound 4, half-maximal inhibitory concentration: >= 600000 nM
Compound 4: a limit, no number; the forecaster's own chance of this, stated with the estimate: 20%; at least 1.4-fold (0.15 log units) between middle value and limit.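

Compound 4 gives only a limit, not a number, in this assay: the limit of >= 600000 nM in this assay, at which 2 of the 4 values shown sit.

Placing 4-methylphenyl on this aromatic nitrogen gives an at least 1.7-fold higher number from compound 3 to compound 4 (0.23 log units; that floor lies within the scatter), and replacing 3-chlorophenyl with it gives an at least 1.2-fold higher number from compound 2 to compound 4 (0.08 log units; that floor lies within the scatter), so neither step shows a real change. The step linking compound 1 and compound 4 cannot be read, as both values are limits.

As far as these compounds go, the true value of compound 4 remains open, as does whether an amine or a carboxylic acid on this nitrogen would move the number beyond the scatter.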